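A few compounds are considered here, and "the series" means these few. Any claim that something is new, unique, unknown or untested is made for them only; others in the source may bear on it.

Of the compounds shown here, three built on one shared core have been tested in an assay on cells for displacement of a labelled ligand from adenosine receptor A3 (Homo sapiens), read by scintillation counting and radioligand binding, with a stated time of 180 min, tested at 10 uM; a higher number here means more inhibition at the concentration tested (going by the name of the read-out), a lower number less inhibition. Compound 3 `CN1CCN(c2nc(-c3cccc(O)c3)nc3[nH]cnc23)CC1` gives > 80%, which is a limit of the assay rather than a number. Compound 2 `Oc1cccc(-c2nc(N3CCCCC3)c3nc[nH]c3n2)c1` likewise reaches > 80%, again a limit and not a number. The two cores differ by piperidin-1-yl in place of 4-methylpiperazin-1-yl on an aromatic carbon; the step that the two limits leave unreadable from compound 2 to compound 3 cannot be read because of the limit of > 80% in this assay, at which 2 of the 3 values shown sit. Compound 1 `CN1CCN(c2nc(-c3cccc(O)c3)nc3c2ncn3C)CC1` gives 63.8%. For the measured compounds named here, it differs from compound 3 by methyl in place of hydrogen on an aromatic nitrogen, and the step of a number at least 16.2 percentage points lower from compound 3 to compound 1 (beyond the scatter) is the one readable change so far. Compound 4 `Cn1cnc2c(N3CCCCC3)nc(-c3cccc(O)c3)nc21` is not yet measured; it differs from compound 2 by methyl in place of hydrogen on an aromatic nitrogen, the same change at the same place. The expected step is a number at least 18 percentage points lower from compound 2 to compound 4 (beyond the scatter), because compound 1 gives 63.8% after this change. Compound 4 is therefore estimated at 62%, with a likely range from 42% to 80%.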

Compound 4, a percentage reported as inhibition, at one concentration (the size of the read-out at that concentration, not a potency): 49.1%
Beside the measured number, compound 4's estimate is 12.9 percentage points above it; the range from low to high includes it.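

Methyl in place of hydrogen on an aromatic nitrogen gives a number at least 30.9 percentage points lower from compound 2 to compound 4 (beyond the scatter) in this assay, and the direction of the change is the same on the core of compound 3, so it carries over in these two cases: the same change on two cores in this assay, a number at least 16.2 percentage points lower (beyond the scatter) from compound 3 to compound 1 and a number at least 30.9 percentage points lower (beyond the scatter) from compound 2 to compound 4; the limit leaves it open whether they differ. With the methyl in place, piperidin-1-yl in place of 4-methylpiperazin-1-yl gives a number 14.7 percentage points lower from compound 1 to compound 4 (beyond the scatter), whereas the same swap without the methyl cannot be read. Going by these compounds, it also stays unknown whether the methyl change is larger on one core than on the other: the limit of > 80% in this assay, at which 2 of the 4 values shown sit.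

The compounds shown leave open how a longer chain, such as ethyl, would read on that aromatic nitrogen. They also leave open how a different amine, such as morpholin-4-yl, would read on the aromatic carbon.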